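A Methoxy Removed: What the Mice Might Show

A few compounds are considered here, and "the series" means these few. Any claim that something is new, unique, unknown or untested is made for them only; others in the source may bear on it.

Compound 1 `COc1cc(OC)c(OC)cc1/C=C/COC(=O)/C=C/c1ccc(OC)c(OC)c1`: 100%
Compound 2 `COc1cc(OC)c(OC)cc1/C=C/COC(=O)/C=C/c1c(OC)ccc(OC)c1OC`: 100%

Among the measured compounds shown here, in a functional assay on the whole organism (strain Kunming) with Mus musculus as the target, with a stated time of 0.5 h, at a dose of 300 mg/kg by the intraperitoneal route (a higher number here means a weaker effect of the compound at the dose given, a lower number a stronger effect), compound 1 gives 100%, and compound 2 gives 100%; the two stand level within the scatter, so the numbers so far give no spread to build on. Compound 3 `COc1ccc(/C=C/C(=O)OC/C=C/c2cc(OC)c(OC)cc2OC)cc1` differs from compound 1 by hydrogen in place of methoxy on an aromatic carbon. For the measured compounds named here, no step between measured compounds exists here, so the size that this change brings is unknown; the step from compound 1 to compound 3 is expected to stay within the scatter, if anything toward a lower number. Compound 3 is therefore expected to give 95%, within 70% to 100%, the expected step being a number 5 percentage points lower from compound 1 to compound 3 (within the scatter).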

Compound 3, a percentage reported as activity, at one dose (the size of the read-out at that dose, not a potency): 100%
Beside the measured number, compound 3's estimate is 5 percentage points below it; the measured number falls inside the stated range.
By their numbers in this assay, from the lowest: compounds 1, 2 and 3 (each within the scatter of the next).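

In this assay, among the compounds shown here, replacing 3,4-dimethoxyphenyl with 4-methoxyphenyl gives no change at the digits printed from compound 1 to compound 3 (within the scatter), the first step here that can be read for a single change. The methoxy at this position can therefore give way to hydrogen without a visible shift in the read-out, though all three compounds stand level, so the series has no spread against which a loss could show. No measured evidence explains this result.

Going by these compounds, whether an amine, a hydroxyl or a carboxylic acid at this position would move the number remains open. So does the effect of any change elsewhere on the shared core.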